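A methoxy-to-methyl swap on the aryl ring of compound 3

The source may report more compounds than this note shows. Statements on the series, on what has been measured and on what is new or still open speak of the compounds shown alone.

The three measured compounds share one core. Compound 1 `CCOC(=O)C1=Cc2ccccc2OC1(OCc1cc(-c2ccc(OC)cc2)no1)C(F)(F)F` carries an ethyl ester; in a functional assay on A549 cells (Homo sapiens) for inhibition, read by MTT assay, with a stated time of 24 h (on this read-out lower numbers stand for stronger inhibition and higher numbers for weaker inhibition), compound 1 gives > 150000 nM, which is a limit of the assay rather than a number. Compound 3 `COc1ccc(-c2cc(COC3(C(F)(F)F)Oc4ccccc4C=C3C(=O)O)on2)cc1` carries the free acid instead, and in this assay compound 3 gives 36200 nM; the step of an at least 4.1-fold lower number from compound 1 to compound 3 (0.61 log units; beyond the scatter) reflects hydrogen in place of ethyl on an oxygen next to a carbonyl group. Compound 2 `CCOC(=O)C1=Cc2ccccc2OC1(OCc1cn(-c2ccc(F)c([N+](=O)[O-])c2)nn1)C(F)(F)F` gives 11900 nM in this assay. Among the two numbers shown, compound 3 therefore stands highest, with compound 2 a step beyond the scatter below it.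

Compound 4 `Cc1ccc(-c2cc(COC3(C(F)(F)F)Oc4ccccc4C=C3C(=O)O)on2)cc1` differs from compound 3 only by methyl in place of methoxy on an aromatic carbon. Going by the values given here, no measured step touches this position; the only step recorded concerns the ester oxygen. Without a comparable precedent, no change beyond the scatter is expected, so the estimated step is a 1.0-fold lower number from compound 3 to compound 4 (0.00 log units; within the scatter), and compound 4 is expected to give about 36000 nM in this assay, between 12000 nM and 110000 nM.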

Compound 4, half-maximal inhibitory concentration: 51200 nM
For compound 4 the middle estimate is 1.4-fold (0.15 log units) below the measured one; measured number inside the range.
By their numbers in this assay, from the lowest: compound 2; then compounds 3 and 4 (each within the scatter of the next). At a limit, above all of these: compound 1.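

Among compound 1, compound 2 and compound 3, the only recorded step concerned the ester oxygen, so nothing yet spoke to the aryl ring. In this assay, the change from 4-methoxyphenyl to 4-methylphenyl on the free acid gives a 1.4-fold higher number from compound 3 to compound 4 (0.15 log units; within the scatter), which shows that, at this place para to a large group, losing the methoxy oxygen does not register beyond the scatter. Compound 1 alone gives a limit and not a number: the limit of > 150000 nM in this assay, at which 1 of the 4 values shown sits.

Going by these compounds alone, what a hydroxyl group, an amine or a longer chain such as butoxy would do at this position remains open, since methoxy and methyl are the only groups compared there. Whether the same swap would behave alike on the ethyl ester also stays unanswered.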